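Lipophilicity notes: aryl change on compound 2

The compounds below may be only part of what the source reports. "The series", "measured", "known", "first", "only" and "open" are said of these compounds alone.

Compound 1 (`C[C@H]1CC[C@@H]2[C@@H](OC(=O)[C@]23CC(c2ccc(N(C)C)cc2)=NO3)[C@]2(C)C(=O)C=C[C@@]12O`): 1.51
Compound 2 (`Cc1ccccc1C1C[C@@]2(ON1c1ccccc1)C(=O)O[C@@H]1[C@H]2CC[C@H](C)[C@]2(O)C=CC(=O)[C@@]12C`): 3.64

In a physicochemical assay for lipophilicity (on this read-out higher numbers stand for higher lipophilicity and lower numbers for lower lipophilicity), compound 2 stands highest of the two measured, at 3.64. Compound 1 gives 1.51. The gap between these two values lies beyond the scatter. Compound 3 (`COc1ccc(C2C[C@@]3(ON2c2ccccc2)C(=O)O[C@@H]2[C@H]3CC[C@H](C)[C@]3(O)C=CC(=O)[C@@]23C)cc1Br`) carries 3-bromo-4-methoxyphenyl in place of 2-methylphenyl on a saturated ring carbon. Going by the values given here, no measured pair shows this change, so the expectation rests on the structures alone. A small rise in this assay is expected. The expected change is a number 0.36 log units higher from compound 2 to compound 3 (beyond the scatter). The estimate for compound 3 is 4, with an expected range of 3.5 to 4.5.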

Compound 3, partition coefficient: 3.98
For compound 3 the middle estimate is 0.02 log units above the measured one, and the stated range covers the measured number.
By their numbers in this assay, from the lowest: compound 1; then compound 2; then compound 3.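

Going by these compounds alone, the first single-place step falls at this saturated ring carbon: in this assay, 3-bromo-4-methoxyphenyl in place of 2-methylphenyl gives a number 0.34 log units higher from compound 2 to compound 3 (beyond the scatter), a modest change beyond the scatter. The entering group brings oxygen and bromine while keeping the six-membered aromatic ring of carbon only. Nothing at hand accounts for the step. Bromine and methoxy enter together, so their separate contributions stay unresolved. From the compounds shown here alone, how this assay responds to an amine or a carboxylic acid on this aryl ring also remains open.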